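Swapping one aryl ketone group on a cytotoxicity series

This account rests on a few compounds, and the source may have more. Where it says the series, first, only, none or still open, it means among the compounds named here.

Measured compounds:
Compound 1 `Cc1cc(C)cc(C(=O)c2cc(Cl)ccc2Oc2cc(C)nc(Nc3ccc(C#N)cc3)n2)c1` — 37100 nM
Compound 2 `Cc1cc(Oc2ccc(Cl)cc2C(=O)c2ccccc2C)nc(Nc2ccc(C#N)cc2)n1` — 4240 nM
Compound 3 `Cc1cc(C)cc(C(=O)c2cc(Cl)ccc2Oc2nc(Nc3ccc(C#N)cc3)ncc2C)c1` — 13400 nM

All three were tested in an ADME assay on MT4 cells (Homo sapiens) for cytotoxicity, read by MTT assay, with a stated time of 5 days; on this read-out lower numbers stand for higher toxicity in this test and higher numbers for lower toxicity in this test. Compound 1 and compound 2 share a core and differ in one place: 2-methylphenyl in place of 3,5-dimethylphenyl on a carbonyl carbon. That change gave an 8.8-fold lower number from compound 1 to compound 2 (0.94 log units; beyond the scatter). Compound 4 `Cc1ccccc1C(=O)c1cc(Cl)ccc1Oc1nc(Nc2ccc(C#N)cc2)ncc1C` has not yet been measured; it is built from compound 3 by the same change at the same place: 2-methylphenyl in place of 3,5-dimethylphenyl on a carbonyl carbon. Compound 3 and compound 1 are made of the same atoms joined differently, and the difference between the two cores is not broken down here; in this assay compound 3 gave a number between those of compound 1 and compound 2.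

For the measured compounds named here, because the step of an 8.8-fold lower number from compound 1 to compound 2 (0.94 log units; beyond the scatter) is the only measured instance of this change, the expectation for compound 4 rests on it alone, applied to the value of compound 3. Compound 4 is therefore expected to show a 7.4-fold lower number from compound 3 to compound 4 (0.87 log units; beyond the scatter), giving an estimate of about 1800 nM, with a range from 600 nM to 6000 nM.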

Compound 4, half-maximal cytotoxic concentration: 24200 nM
Beside the measured number, compound 4's estimate is 13-fold (1.13 log units) below it; measured number above the stated range.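

In this assay, putting 2-methylphenyl in place of 3,5-dimethylphenyl on a carbonyl carbon gave a 1.8-fold higher number from compound 3 to compound 4 (0.26 log units; within the scatter), so on this core the change produced no shift that can be told from the usual scatter. The result on one core did not carry over to the other, and the two steps clearly differ: the same change on two cores in this assay, an 8.8-fold lower number (0.94 log units; beyond the scatter) from compound 1 to compound 2 and a 1.8-fold higher number (0.26 log units; within the scatter) from compound 3 to compound 4, 16-fold (1.20 log units) apart, beyond the scatter of two such steps This shows that the outcome of this change depended on the core in these two pairs, but two pairs give no general rule and do not show which feature of the cores is responsible.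

From the compounds shown here alone, it remains open how a plain phenyl or a 2-ethylphenyl on the carbonyl carbon would behave on either core. Going by these compounds, it is also open which of the two steps a further core would resemble.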